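The source may report more compounds than this note shows. Statements on the series, on what has been measured and on what is new or still open speak of the compounds shown alone.

Measured so far:
compound 1 `Fc1cccc(F)c1Cn1c(-c2c(F)cccc2F)nc2cnccc21` — > 100000 nM
compound 2 `Fc1ccccc1Cn1ccc2nc(-c3ccccc3)nc-2c1` — > 100000 nM

In an ADME assay on MDBK cells (Bos taurus) for cytotoxicity (on this read-out lower numbers stand for higher toxicity in this test and higher numbers for lower toxicity in this test), compound 1 gives > 100000 nM, which is a limit of the test rather than a number. In this assay compound 2 likewise gives > 100000 nM, again a limit. Both values sit at the limit of > 100000 nM in this assay, at which 2 of the 2 values shown sit, so compound 2 stands at the ceiling of what this assay can report, with nothing to set it apart from compound 1.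

Compound 3 `N#Cc1ccc(Cn2ccc3nc(-c4ccccc4)nc-3c2)cc1` is not yet measured. It differs from compound 2 by 4-cyanophenyl in place of 2-fluorophenyl on a saturated chain carbon bound to an aromatic nitrogen. No change beyond the scatter is expected here; the step of a number no higher from compound 2 to compound 3 (the limit leaves the size open) is an estimate only. Compound 3 is expected to give about 100000 nM, in the range 50000 nM to 200000 nM.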

Compound 3, half-maximal cytotoxic concentration: > 100000 nM
Compound 3 ended at the assay's limit; the forecaster's own chance of this, stated with the estimate: 80%; the middle value lies on the limit itself.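

Compound 3, like compound 2, stands at the limit of this assay, so the step between them cannot be read: the limit of > 100000 nM in this assay, at which 3 of the 3 values shown sit.

The compounds shown leave open how far their true values lie past that limit, and whether any structural change would bring a readable number.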